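A few compounds are considered here, and "the series" means these few. Any claim that something is new, unique, unknown or untested is made for them only; others in the source may bear on it.

Values in a functional assay on HCT-116 cells (Homo sapiens) for inhibition, read by CCK-8 assay, with a stated time of 48 h (a higher number here means a weaker inhibitor, a lower number a stronger inhibitor), so far:
compound 1 `COc1ccc(CN(C(=O)CSC(=S)N2CCN(C(=O)OC(C)(C)C)CC2)c2cc(OC)c(OC)c(OC)c2)cc1` gives 620 nM
compound 2 `COc1ccc(CN(C(=O)CSC(=S)N2CCN(Cc3ccc(C(C)(C)C)cc3)CC2)c2cc(OC)c(OC)c(OC)c2)cc1` gives 6890 nM
compound 3 `COc1ccc(CN(C(=O)CSC(=S)N2CCc3ccccc32)c2cc(OC)c(OC)c(OC)c2)cc1` gives 7710 nM

Compound 3 sits within the scatter of compound 2, and both carry clearly higher numbers than compound 1. Compound 4 `COc1ccc(CN(C(=O)CSC(=S)N2CCc3ccccc3C2)c2cc(OC)c(OC)c(OC)c2)cc1` has 1,2,3,4-tetrahydroisoquinolin-2-yl in place of 2,3-dihydro-1H-indol-1-yl on a thiocarbonyl carbon. Among the compounds with values here, the only measured step, an 11-fold higher number from compound 1 to compound 2 (1.05 log units; beyond the scatter), is large, but it concerns a different exchange and does not test this one. Within the data shown here, with no direct precedent, no step beyond the scatter is expected in this assay, and no direction can be favoured. The expected step is a 1.3-fold lower number from compound 3 to compound 4 (0.11 log units; within the scatter). For compound 4 the estimated value is 6000 nM, with an expected range of 2000 nM to 16000 nM.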

Compound 4, half-maximal inhibitory concentration: 15900 nM
Compound 4: the middle estimate sits 2.7-fold (0.42 log units) below what was measured; the measured number falls inside the stated range.
By their numbers in this assay, from the lowest: compound 1; then compounds 2 and 3 (each within the scatter of the next); then compound 4.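

On a thiocarbonyl carbon, 1,2,3,4-tetrahydroisoquinolin-2-yl in place of 2,3-dihydro-1H-indol-1-yl gives in this assay a 2.1-fold higher number from compound 3 to compound 4 (0.31 log units; beyond the scatter). This position therefore registers even this small exchange, a six-membered for a five-membered non-aromatic ring, with hydrogen-bond donor and acceptor counts unchanged, although the step is modest. No measured evidence on hand accounts for this step.

Open, as far as these compounds go, is how a morpholine or a piperidine would read on the thiocarbonyl carbon. Also open, from the compounds shown here alone, is whether a free amine in place of tert-butoxycarbonyl on the amine nitrogen in a ring would keep the number of compound 1, 620 nM.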